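Propyl to Isopropyl on Two Cores in a Cytotoxicity Assay

The compounds below may be only part of what the source reports. "The series", "measured", "known", "first", "only" and "open" are said of these compounds alone.

Compound 1 `CCCc1ccc(-c2ccc3ncc(C(=O)OCC)cc3c2)cc1` and compound 2 `CCOC(=O)c1cnc2ccc(-c3ccc(C(C)C)cc3)cc2c1` share a core and differ by isopropyl in place of propyl on an aromatic carbon. In a functional assay on RD cells (Homo sapiens) for inhibition, read by luminescence and ATP content, with a stated time of 72 h (a higher number here means that more compound is tolerated, a lower number that less compound is tolerated), compound 1 reaches only the limit > 7400 nM, a limit rather than a number. Compound 2 likewise sits at the limit > 7400 nM in this assay. The step that the two limits leave unreadable from compound 1 to compound 2 therefore cannot be read, because the limit of > 7400 nM in this assay, at which 2 of the 3 values shown sit, holds both values.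

Compound 3 `CCCc1nc(-c2cnc3ccc(-c4ccc(N)cc4)cc3c2)no1` carries a different core; how the two cores differ is not broken down here. In this assay compound 3 gives the limit > 800 nM, again a limit and not a number, as the limit of > 800 nM in this assay, at which 1 of the 3 values shown sits, records.

Compound 4 `CC(C)c1nc(-c2cnc3ccc(-c4ccc(N)cc4)cc3c2)no1` differs from compound 3 by isopropyl in place of propyl on an aromatic carbon. This is the same kind of change as that from compound 1 to compound 2, but the place differs: there it sat on a six-membered aromatic ring of carbon only, para to a large group, here on a five-membered aromatic ring with two nitrogen and one oxygen, next to the ring nitrogen and the ring oxygen. Since compound 3 shows only a limit, the step from compound 3 to compound 4 is expected to be about a step that the limit leaves unreadable from compound 3 to compound 4, and compound 4 is estimated at 1500 nM, between 600 nM and 6000 nM.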

Compound 4, half-maximal cytotoxic concentration: > 800 nM
Compound 4 ended at the assay's limit; the forecaster's own chance of this, stated with the estimate: 75%; the middle value lies beyond the limit too.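

Compound 3 and compound 4 both stop at the same limit in this assay, a limit and not a number, so no step between them can be read: the limit of > 800 nM in this assay, at which 2 of the 4 values shown sit.

The compounds shown leave open how far any of them lies past its limit, and whether isopropyl in place of propyl makes any difference on either core.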